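The compounds below may be only part of what the source reports. "The series", "measured", "known", "first", "only" and "open" are said of these compounds alone.

Measured so far, in a functional assay on the whole organism (strain Wistar) with Rattus norvegicus as the target, with a stated time of 5 min; a higher number here means that more compound is needed for the effect, a lower number that less compound is needed:
Compound 1, `CCC1(CCCCN2CCN(c3ccc(C)c(Cl)c3)CC2)C(=O)Nc2ccccc21`, reaches only a limit of the assay, > 20 mg/kg.
Compound 2, `CCC1(CCCCN2CC=C(c3ccc(Cl)cc3)CC2)C(=O)Nc2ccccc21`, likewise reaches only a limit of the assay, > 20 mg/kg.

For the measured compounds named here, compound 2 thus stands not at a number but at a limit of this assay, in the same place as the one other measured value; the two measured values share (the limit of > 20 mg/kg in this assay, at which 2 of the 2 values shown sit). Going by the values given here, no step between two measured compounds is available to guide a reading of the next change. Compound 3, `CCC1(CCCCN2CC=C(c3ccc(F)cc3)CC2)C(=O)Nc2ccccc21`, differs from compound 2 in one place: fluoro in place of chloro on an aromatic carbon. The measured values give no sign of what such an exchange does here, so in this assay no step beyond the usual scatter is expected, in either direction. Compound 3 is therefore expected to come out near 25 mg/kg, within 10 mg/kg to 60 mg/kg, most likely again as a limit rather than a number. The expected step that the limit leaves unreadable from compound 2 to compound 3 is small.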

Compound 3, minimum effective dose: 20 mg/kg
Compound 3: middle estimate off by 1.3-fold (0.10 log units), on the high side; the range from low to high includes it.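

In this assay, compound 3 is the only compound here with an actual number, 20 mg/kg, while the other values remain at the edge of what the assay can read: the limit of > 20 mg/kg in this assay, at which 2 of the 3 values shown sit.

The change from 4-chlorophenyl to 4-fluorophenyl gives a number no higher from compound 2 to compound 3 (the limit leaves the size open). As far as these compounds go, this shows that the aromatic carbon para to a large group can carry fluoro and still give a dose the assay can read, although how far compound 3 really lies from compound 2 remains unknown.

From the compounds shown here alone, what a bromo group, a methoxy group or a plain hydrogen would do at this place stays open. Going by these compounds, it is also open whether any group here could bring the dose well under the limit.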